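The source may hold more compounds than are shown below. What is called first, only, known or untested is meant among the compounds shown, and "the series" means these compounds.

Measured in a functional assay on A549 cells (Homo sapiens) for inhibition, read by MTT assay, with a stated time of 48 h; a lower number here means a stronger inhibitor, a higher number a weaker inhibitor:
- Compound 1 `COc1ccc(C/N=C2\NC(=O)/C(=C3\CCNC(=O)c4[nH]ccc43)S2)cc1`: 18300 nM
- Compound 2 `O=C1N/C(=N\Cc2ccc(C(F)(F)F)cc2)S/C1=C1/CCNC(=O)c2[nH]ccc21`: > 100000 nM (a limit of the assay, not a number)
- Compound 3 `O=C1N/C(=N\Cc2cccc(Cl)c2)S/C1=C1/CCNC(=O)c2[nH]ccc21`: 35200 nM

Compound 1 sits at the low, stronger end of these numbers, and its nearest neighbour shows a 1.9-fold higher number from compound 1 to compound 3 (0.28 log units; within the scatter). Compound 4 `COc1ccc(C/N=C2\NC(=O)/C(=C3\CCNC(=O)c4c3ccn4C)S2)cc1` keeps the core of compound 1 and alters one place: methyl in place of hydrogen on an aromatic nitrogen. This puts a methyl in place of hydrogen on an aromatic nitrogen.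

For the measured compounds named here, no measured step touches that nitrogen, so the evidence is only indirect. Both measured steps change the substituted phenyl group instead. One of them, an at least 5.4-fold higher number from compound 1 to compound 2 (0.73 log units; beyond the scatter), shows that a single change can raise the number beyond the scatter, while the other stays within it. In this assay, a modest rise is therefore expected, though little more than the scatter and with wide uncertainty.

The expected step is a 1.6-fold higher number from compound 1 to compound 4 (0.21 log units; within the scatter).

For compound 4 the estimated value is 30000 nM, with an expected range of 10000 nM to 90000 nM.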

Compound 4, half-maximal inhibitory concentration: > 100000 nM
Compound 4: only a limit was reported; the forecaster's own chance of this, stated with the estimate: 15%; middle value at least 3.3-fold (0.52 log units) from the limit.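

For the compounds shown here, the earlier steps changed only the substituted phenyl group, so this is the only evidence here on the aromatic nitrogen of the shared core. In this assay, replacing the hydrogen on that nitrogen with methyl, a change of a single heavy atom, gives an at least 5.4-fold higher number from compound 1 to compound 4 (0.73 log units; beyond the scatter), so this position is not free to change in this series, even though the phenyl group had already shown a step within the scatter. That step is only a minimum, set by a limit of the assay, so compound 2 and compound 4 cannot be ranked against each other: the limit of > 100000 nM in this assay, at which 2 of the 4 values shown sit.

As far as these compounds go, whether the loss is specific to methyl remains open, since an ethyl group or a longer chain on the same nitrogen could behave differently. It is also unclear whether methyl has the same effect alongside the 3-chlorophenyl group of compound 3.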